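This account rests on a few compounds, and the source may have more. Where it says the series, first, only, none or still open, it means among the compounds named here.

Values in a functional assay on NCI-H1975 cells (Homo sapiens) for inhibition, read by sulforhodamine B assay, tested at 10 uM (on this read-out lower numbers stand for less inhibition and higher numbers for more inhibition at the one concentration tested (going by the name of the read-out)), for the measured members of the series:

compound 1, `CN1CCN(c2ccc(C3=NN(C(=O)/C=C/c4ccccc4)C(c4ccc(N(C)C)cc4)C3)cc2)CC1`: 81%
compound 2, `CN1CCN(c2ccc(C3=NN(S(C)(=O)=O)C(c4ccc(N(C)C)cc4)C3)cc2)CC1`: -1.3%
compound 3, `CN(C)c1ccc(C2CC(c3ccc(-n4cncn4)cc3)=NN2C(=O)/C=C/c2ccccc2)cc1`: -2.3%

The change methylsulfonyl in place of (2-phenylethenyl)carbonyl on an amine nitrogen in a ring gives a number 82.3 percentage points lower from compound 1 to compound 2 (beyond the scatter). The two cores differ by 1H-1,2,4-triazol-1-yl in place of 4-methylpiperazin-1-yl on an aromatic carbon, which gives a number 83.3 percentage points lower from compound 1 to compound 3 (beyond the scatter). Compound 2 and compound 3 show values of about the same size in this assay.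

Compound 4, `CN(C)c1ccc(C2CC(c3ccc(-n4cncn4)cc3)=NN2S(C)(=O)=O)cc1`, is not yet measured. It differs from compound 3 by methylsulfonyl in place of (2-phenylethenyl)carbonyl on an amine nitrogen in a ring. This is the same kind of change as that from compound 1 to compound 2; the surroundings differ in that the ring atom two ring bonds away bears a 4-(1H-1,2,4-triazol-1-yl)phenyl group in compound 3, where in compound 1 it bears a large group. The step from compound 3 to compound 4 in this assay is expected to be much smaller than the earlier one, because compound 3 already gives -2.3% and there is little room left to fall; the expected step is a number 1.3 percentage points higher from compound 3 to compound 4 (within the scatter). Compound 4 is estimated at -1%, between -14% and 12%.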

Compound 4, a percentage reported as inhibition, at one concentration (the size of the read-out at that concentration, not a potency): -3.1%
For compound 4 the middle estimate is 2.1 percentage points above the measured one; the measured number falls inside the stated range.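

In this assay, methylsulfonyl in place of (2-phenylethenyl)carbonyl on the amine nitrogen in the ring gives a number 0.8 percentage points lower from compound 3 to compound 4 (within the scatter), and 1H-1,2,4-triazol-1-yl in place of 4-methylpiperazin-1-yl gives a number 1.8 percentage points lower from compound 2 to compound 4 (within the scatter). The first change does not carry its size over from the core of compound 1 to the core of compound 3: the same change on two cores in this assay, a number 82.3 percentage points lower (beyond the scatter) from compound 1 to compound 2 and a number 0.8 percentage points lower (within the scatter) from compound 3 to compound 4, 81.5 percentage points apart, beyond the scatter of two such steps

The second change likewise depends on its core, but the small steps do not show that either change is without effect in general, since compound 2, compound 3 and compound 4 all sit near zero, where a further fall would hardly be visible: the same change on two cores in this assay, a number 83.3 percentage points lower (beyond the scatter) from compound 1 to compound 3 and a number 1.8 percentage points lower (within the scatter) from compound 2 to compound 4, 81.5 percentage points apart, beyond the scatter of two such steps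

Open, from the compounds shown here alone, is whether another amine such as morpholin-4-yl in place of 4-methylpiperazin-1-yl, or another acyl group such as acetyl or benzoyl in place of (2-phenylethenyl)carbonyl, would keep a number close to that of compound 1. Also open, going by these compounds, is the potency of compound 1, as a reading at one concentration gives none.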